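Hydroxamate series: N-acyl variation at the ring nitrogen

A few compounds are considered here, and "the series" means these few. Any claim that something is new, unique, unknown or untested is made for them only; others in the source may bear on it.

Measured compounds:
compound 1 `COc1ccc(NC(=O)[C@@H]2Cc3ccc(OCC(=O)NO)cc3CN2C(=O)[C@@H]2CCCN2C(=O)OC(C)(C)C)cc1` 212 nM
compound 2 `COc1ccc(NC(=O)[C@@H]2Cc3ccc(OCC(=O)NO)cc3CN2CCCc2ccccc2)cc1` 1720 nM
compound 3 `COc1ccc(NC(=O)[C@@H]2Cc3ccc(OCC(=O)NO)cc3CN2C(=O)[C@@H]2CCCN2)cc1` 481 nM

In an assay on isolated protein for inhibition of histone deacetylase 8 (Homo sapiens), read by fluorescence, with a stated time of 30 min (a higher number here means a weaker inhibitor, a lower number a stronger inhibitor), compound 1 gives the lowest number of the three; compound 3 comes nearest, compound 2 furthest. Compound 4 `CC[C@H](C)[C@H](N)C(=O)N1Cc2cc(OCC(=O)NO)ccc2C[C@H]1C(=O)Nc1ccc(OC)cc1` differs from compound 1 by 1-amino-2-methylbutyl in place of 1-(tert-butoxycarbonyl)pyrrolidin-2-yl on a carbonyl carbon. For the measured compounds named here, the step that bears on this is the loss of the tert-butoxycarbonyl group, a 2.3-fold higher number from compound 1 to compound 3 (0.36 log units; beyond the scatter), which also leaves a free amine; the swap of a ring for the 1-amino-2-methylbutyl chain has no measured counterpart, while a 3.6-fold lower number from compound 2 to compound 3 (0.55 log units; beyond the scatter) only shows the acyl group is preferred over an alkyl chain. A modest weakening of similar size is therefore expected, a 2.1-fold higher number from compound 1 to compound 4 (0.33 log units; beyond the scatter). Compound 4 is estimated at 450 nM, range 180 nM to 1100 nM.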

Compound 4, half-maximal inhibitory concentration: 1040 nM
Beside the measured number, compound 4's estimate is 2.3-fold (0.36 log units) below it; low and high end bracket the measured number.
By their numbers in this assay, from the lowest: compound 1; then compound 3; then compounds 4 and 2 (each within the scatter of the next).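

In this assay, the step of a 2.2-fold higher number from compound 3 to compound 4 (0.33 log units; beyond the scatter) isolates the change of pyrrolidin-2-yl to the open 1-amino-2-methylbutyl chain, with a free amine present in both compounds. The full change on this carbonyl carbon gives a 4.9-fold higher number from compound 1 to compound 4 (0.69 log units; beyond the scatter) and is larger in printed size than the loss of tert-butoxycarbonyl alone. The preference for acyl over 3-phenylpropyl seen with compound 3 does not hold for this chain, with a 1.7-fold lower number from compound 2 to compound 4 (0.22 log units; within the scatter) as the step.

No data here explain these shifts. As far as these compounds go, whether a piperidin-2-yl group or a tert-butoxycarbonyl group on the chain amine would lower the number remains open.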